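The compounds below may be only part of what the source reports. "The series", "measured", "known", "first", "only" and "open" are said of these compounds alone.

Of the compounds shown here, three built on a shared core have so far been tested in an assay for inhibition of Indoleamine 2,3-dioxygenase 1 (Homo sapiens), with stated times of 10 min and 60 min, tested at 10 uM; a lower number here means a weaker effect, a higher number a stronger effect of the compound at the concentration tested. Compound 1, `O=[N+]([O-])c1cc(OCc2ccccc2)ccc1CNc1cc(C(F)(F)F)cc2[nH]ncc12`, gives 10%. Compound 2, `FC(F)(F)c1cccc(CNc2cc(C(F)(F)F)cc3[nH]ncc23)c1`, gives 25%. Compound 3, `O=[N+]([O-])c1cc(Br)c(F)cc1CNc1cc(C(F)(F)F)cc2[nH]ncc12`, gives 31%. Among these three numbers compound 2 stands second highest. Its nearest neighbour is compound 3, whose number lies higher by an amount within the usual scatter, so no order between compound 2 and compound 3 can be claimed; its furthest neighbour is compound 1, whose number lies lower by an amount beyond the scatter.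

Compound 4, `Nc1cccc(CNc2cc(C(F)(F)F)cc3[nH]ncc23)c1`, has not yet been measured. It differs from compound 2 in a single place: amino in place of trifluoromethyl on an aromatic carbon. Among the compounds with values here, no pair of measured compounds in this set differs in this way. The size of the step can only be estimated rather than read from the data. Given that the three measured values all fall in a modest range, the step in this assay from compound 2 to compound 4 is expected to be small, more likely downward than upward, and possibly within the scatter, a number 7 percentage points lower from compound 2 to compound 4 (within the scatter). Compound 4 is therefore estimated to give 18% in this assay, with an expected range from 4% to 34%.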

Compound 4, a percentage reported as inhibition, at one concentration (the size of the read-out at that concentration, not a potency): 24%
Compound 4: the middle estimate sits 6 percentage points below what was measured; measured number inside the range.
By their numbers in this assay, from the lowest: compound 1; then compounds 4, 2 and 3 (each within the scatter of the next).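

In this assay, within the data shown here, the exchange of trifluoromethyl for amino on an aromatic carbon, meta to a large group, amounts to a number 1 percentage points lower from compound 2 to compound 4 (within the scatter), the first single-place step that can be read in this set. Compound 2 alone had shown only that trifluoromethyl at this position is compatible with a read-out in the range of the other compounds, whereas this pair shows that the read-out stays within the scatter when a group of 4 heavy atoms with 0 hydrogen-bond donors and 0 hydrogen-bond acceptors gives way to one of 1 heavy atom with 1 hydrogen-bond donor and 1 hydrogen-bond acceptor. No measurement in hand explains why the two groups cannot be told apart in this assay.

On these data alone, whether a hydroxyl, a methoxy, a nitrile or a carboxylic acid on this same aromatic carbon would also stay within the scatter of compound 2 remains open, as does the outcome of an acetamide built on the amino group of compound 4. Also open, as far as these compounds go, is whether the same exchange would give a similarly small step on a compound carrying a nitro group, such as compound 3.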